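A few compounds are considered here, and "the series" means these few. Any claim that something is new, unique, unknown or untested is made for them only; others in the source may bear on it.

So far, two compounds that share a core have numbers in a functional assay on SK-BR-3 cells (Homo sapiens) for cytotoxicity, read by CellTiter-Glo, with a stated time of 72 h; on this read-out lower numbers stand for stronger inhibition and higher numbers for weaker inhibition. Compound 1 `C=CCO/N=C1/[C@@H](OC)C[C@H](C)CC2=C(NCCN(C)C)C(=O)C=C(NC(=O)/C(C)=C/C=C\[C@H](OC)[C@@H](OC(N)=O)/C(C)=C/[C@@H]1C)C2=O` gives 400 nM, and compound 2 `C=CCNC1=C2C[C@@H](C)C[C@H](OC)/C(=N/O)[C@@H](C)/C=C(\C)[C@H](OC(N)=O)[C@@H](OC)/C=C\C=C(/C)C(=O)NC(=CC1=O)C2=O` gives 350 nM. These two values lie within the usual scatter of repeated measurements, so compound 1 stands level with compound 2 and neither can be ranked ahead of the other.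

Compound 3 `CO[C@H]1C[C@H](C)CC2=C(NCCN(C)C)C(=O)C=C(NC(=O)/C(C)=C/C=C\[C@H](OC)[C@@H](OC(N)=O)/C(C)=C/[C@H](C)/C1=N\OCc1ccccc1)C2=O` has not yet been measured. It keeps the core of compound 1 and changes one group: phenyl in place of vinyl on a saturated chain carbon bound to an oxygen on an unsaturated carbon. In short, allyloxy becomes benzyloxy.

Within the data shown here, no measured pair isolates this swap, so the data offer no direct guide to its size or direction. Among the measured compounds shown here, the only anchor is compound 1 at 400 nM. No change beyond the scatter is expected in this assay, and the estimated step is no change at the digits printed from compound 1 to compound 3 (within the scatter). For compound 3 the expected value is 400 nM, with an estimated range of 140 nM to 1100 nM.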

Compound 3, half-maximal inhibitory concentration: 480 nM
Compound 3: middle estimate off by 1.2-fold (0.08 log units), on the low side, within the range that was stated.
By their numbers in this assay, from the lowest: compounds 2, 1 and 3 (each within the scatter of the next).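

In this assay, putting phenyl in place of vinyl on a saturated chain carbon bound to an oxygen on an unsaturated carbon, which turns allyloxy into benzyloxy, gives a 1.2-fold higher number from compound 1 to compound 3 (0.08 log units; within the scatter). Among these compounds, this pair is the first direct reading of this position, and it shows that a six-membered aromatic ring can stand in place of vinyl here without a step beyond the scatter. Nothing in the available data speaks to why the two groups read alike.

Neither phenyl nor vinyl carries a hydrogen-bond donor, a hydrogen-bond acceptor or a net charge, so the compounds shown leave open how this position responds to an amine or a carboxylic acid in their place. Also open, from the compounds shown here alone, is what a longer chain carrying the phenyl ring would give on the same oxygen.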